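The compounds below may be only part of what the source reports. "The series", "measured", "known", "first", "only" and "open" are said of these compounds alone.

Among the measured compounds shown here, in an ADME assay on microsomes from liver (Mus musculus) for metabolic stability, read by LC-MS, with a stated time of 30 min, tested at 1 uM (a higher number here means that more of the compound is left, a lower number that less of the compound is left), compound 1 (`CCNCc1cc(C)cc(Nc2nc3ccccc3n2Cc2ccc(C(F)(F)F)cc2)c1O`) gives 52%, the lowest of the three numbers measured so far. Compound 2 (`CCNCc1cc(Cl)cc(Nc2nc3ccccc3n2Cc2ccc(C(F)(F)F)cc2)c1O`) gives 73%, and compound 3 (`CCNCc1cc(Cl)cc(Nc2nc3cc(F)c(F)cc3[nH]2)c1O`) gives 98%. The unmeasured compound 4 (`CCN(CC)Cc1cc(C)cc(Nc2nc3ccccc3n2Cc2ccc(C(F)(F)F)cc2)c1O`) departs from compound 1 at the amine alone: ethyl in place of hydrogen on an amine nitrogen. This is ethyl in place of hydrogen on an amine nitrogen, or (ethylamino)methyl to (diethylamino)methyl. For the measured compounds named here, no measured step covers this change. Going by the values given here, the one single-place step available, a number 21 percentage points higher from compound 1 to compound 2 (beyond the scatter), is chloro in place of methyl on an aromatic carbon. It is modest but beyond the scatter, and it offers a guide to size only, not to direction. Compound 3 differs from the others in more than one place and isolates no single change. A modest step downward in this assay is therefore expected, although this direction is a judgement that the series does not show. The expected step is a number 12 percentage points lower from compound 1 to compound 4 (beyond the scatter). The estimate for compound 4 is 40%, with an expected range of 20% to 62%.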

Compound 4, percent of the compound remaining in the Mus musculus assay: < 7%
Compound 4 gave a limit, no number; the forecaster's own chance of this, stated with the estimate: 2%; middle value at least 33 percentage points from the limit.
By their numbers in the Mus musculus assay, from the lowest: compound 1; then compound 2; then compound 3. At a limit, below all of these: compound 4.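

Compounds 1, 2 and 3 all carry the same ethylamino group, so they said nothing about this amine nitrogen. As far as these compounds go, in the Mus musculus assay, ethyl in place of hydrogen on that nitrogen gives a number at least 45 percentage points lower from compound 1 to compound 4 (beyond the scatter), which shows that this position responds strongly to a small addition, although compound 4 stands at a limit and not at a number, so the full size of the step stays unknown: the limit of < 7% in the Mus musculus assay, at which 1 of the 4 values shown sits. In a physicochemical assay for solubility, read by HPLC, measured as kinetic solubility, with a stated time of 24 h, at pH 6.5 (a higher number here means a more soluble compound, a lower number a less soluble compound), the same change gives an at least 7.0-fold lower number from compound 1 to compound 4 (0.84 log units; beyond the scatter), so the physicochemical assay also moves at this position. In the physicochemical assay compound 1 gives 35000 nM. In the physicochemical assay compound 4 gives < 5000 nM, and compound 4 again stands at a limit: the limit of < 5000 nM in the physicochemical assay, at which 1 of the 2 values shown sits.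

Open, from the compounds shown here alone, is whether methyl or a ring amine such as pyrrolidine on this nitrogen would give a step of similar size. Also open, going by these compounds, is whether the same change would carry over to the chloro-bearing compound 2.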